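Removing the Chloro Group From Compound 2

The source may hold more compounds than are shown below. What is called first, only, known or untested is meant among the compounds shown, and "the series" means these compounds.

Of the compounds shown here, two from this series have been tested in a functional assay on SK-MEL-5 cells (Homo sapiens) for inhibition, read by sulforhodamine B assay, with a stated time of 48 h; on this read-out lower numbers stand for stronger inhibition of growth and higher numbers for weaker inhibition of growth. Compound 1 `N=C(N)c1ccc(-c2ccc(-c3ccc(F)cc3)s2)cc1` gives 1600 nM, and compound 2 `N=C(N)c1ccc(-c2ccc(-c3ccc(Cl)cc3)s2)cc1F` gives 1270 nM; these two numbers lie within the scatter of each other, so neither compound can be separated from the other on this read-out. Compound 3 `N=C(N)c1ccc(-c2ccc(-c3ccccc3)s2)cc1F` has not yet been measured. It differs from compound 2 in one place: hydrogen in place of chloro on an aromatic carbon. Among the compounds with values here, no step between two measured compounds is known here, so the effect of this change cannot be read from the data. The expectation for compound 3 is therefore a modest weakening, likely not beyond the scatter, with a 1.7-fold higher number from compound 2 to compound 3 (0.22 log units; within the scatter) in this assay. Compound 3 is estimated to give 2100 nM in this assay, with a range from 900 nM to 5000 nM.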

Compound 3, concentration for 50% growth inhibition: 3430 nM
Estimate against measurement, compound 3: 1.6-fold (0.21 log units) below, and the stated range covers the measured number.
By their numbers in this assay, from the lowest: compounds 2 and 1 (each within the scatter of the next); then compound 3.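

Within the data shown here, with a single chlorine atom as the only difference, the change from 4-chlorophenyl to phenyl gives in this assay a 2.7-fold higher number from compound 2 to compound 3 (0.43 log units; beyond the scatter), the first step that can be read, and it shows that this position, on an aromatic carbon para to a large group, does respond to what it carries. Compound 1 differs from compound 2 and from compound 3 in more than one place, so it cannot show how much of this step belongs to chloro alone. Nothing at hand explains why the step has this size.

From the compounds shown here alone, what a methoxy group, an amine or a carboxylic acid would do in this place remains open. So does whether hydrogen in place of chloro would give a step of similar size on the core of compound 1.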